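Cytotoxicity at the limit: a smaller group on nitrogen

A few compounds are considered here, and "the series" means these few. Any claim that something is new, unique, unknown or untested is made for them only; others in the source may bear on it.

Working notes on the series, read in an ADME assay on MT4 cells (Homo sapiens) for cytotoxicity, with a stated time of 5 days; on this read-out lower numbers stand for higher toxicity in this test and higher numbers for lower toxicity in this test. Compound 1 `CC(C)(C)C#Cc1cc(N(C(=O)[C@H]2CC[C@H](C)CC2)[C@H]2CC[C@H](OC3CCOCC3)CC2)c(C(=O)O)s1` gives > 20000 nM, a limit of the assay. Compound 2 `CC(C)(C)C#Cc1cc(N(C(=O)[C@H]2CC[C@H](C)CC2)[C@H]2C[C@@H](Oc3cccnc3)C2)c(C(=O)O)s1` gives > 20000 nM, also a limit and not a number. Compound 3 `C[C@H]1CC[C@H](C(=O)N(c2cc(C#CC3(C(F)(F)F)CCC3)sc2C(=O)O)[C@H]2CC[C@H](Oc3ccc(=O)[nH]n3)CC2)CC1` gives > 20000 nM, again a limit. Among the measured compounds shown here, the whole set thus reads (the limit of > 20000 nM in this assay, at which 3 of the 3 values shown sit), and compound 2 stands there with the other two, with no measured step to calibrate against.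

Compound 4 `CC(C)(C)C#Cc1cc(N(CCO)C(=O)[C@H]2CC[C@H](C)CC2)c(C(=O)O)s1` carries 2-hydroxyethyl in place of 3-((pyridin-3-yl)oxy)cyclobutyl on an amide-type nitrogen of compound 2 (2-hydroxyethyl in place of 3-((pyridin-3-yl)oxy)cyclobutyl on an amide-type nitrogen).

No change beyond the usual scatter is expected in this assay, in either direction. This expectation rests on compound 2, whose reading is > 20000 nM, a limit. The expected step is small: a step that the limit leaves unreadable from compound 2 to compound 4. For compound 4 the estimate is 25000 nM, with an expected range of 12000 nM to 60000 nM.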

Compound 4, half-maximal cytotoxic concentration: > 20000 nM
Compound 4 ended at the assay's limit (the forecaster's own chance of this, stated with the estimate: 90%); the middle value lies beyond the limit too.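

No step can be read from compound 2 to compound 4, since both readings are limits and not numbers: the limit of > 20000 nM in this assay, at which 4 of the 4 values shown sit.

The compounds shown leave open whether 2-hydroxyethyl and 3-((pyridin-3-yl)oxy)cyclobutyl on the amide-type nitrogen differ at all in cytotoxicity, and at what concentration any of these compounds becomes cytotoxic.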